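Nitro gives way to amino at the assay limit

This account rests on a few compounds, and the source may have more. Where it says the series, first, only, none or still open, it means among the compounds named here.

Values so far in an ADME assay on NCI-H460 cells (Homo sapiens) for cytotoxicity, read by MTT assay, with a stated time of 72 h (a higher number here means a weaker inhibitor, a lower number a stronger inhibitor), are these.
- Compound 1 (`COc1cccc(-n2nnc(-c3ccccc3NC(=O)c3ccc(N)cc3)n2)c1`) gives > 100000 nM as a limit.
- Compound 2 (`COc1cccc(-n2nnc(-c3ccccc3NC(=O)c3ccc(NC(=O)CBr)cc3)n2)c1`) gives > 100000 nM as a limit.
- Compound 3 (`COc1cccc(-n2nnc(-c3ccccc3NC(=O)Nc3ccc([N+](=O)[O-])cc3)n2)c1`) gives > 100000 nM as a limit.

All three measured compounds therefore give limits rather than numbers, and the series sits at the limit of > 100000 nM in this assay, at which 3 of the 3 values shown sit, with no value to rank them by. Compound 3 stands there with the other two.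

Compound 4 (`COc1cccc(-n2nnc(-c3ccccc3NC(=O)Nc3ccc(N)cc3)n2)c1`) differs from compound 3 at one place, with amino in place of nitro on an aromatic carbon, para to a large group (amino in place of nitro on an aromatic carbon).

Among the compounds with values here, three measured steps bear on this change, and none has a size that can be used. They are a step that the two limits leave unreadable from compound 1 to compound 3 and a step that the two limits leave unreadable from compound 1 to compound 2 and also a step that the two limits leave unreadable from compound 2 to compound 3 in this assay as well. None of them shows a move in either direction, so the data give no ground for expecting a shift beyond the scatter.

The expected move is a number no higher from compound 3 to compound 4 (the limit leaves the size open) and it has no favoured direction. The expectation starts from compound 3 at its limit of > 100000 nM and most likely ends at a limit again. For compound 4 the estimate is 100000 nM with an expected range from 40000 nM to 150000 nM in this assay when measured.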

Compound 4, half-maximal inhibitory concentration: > 100000 nM
Compound 4: a limit, no number; the forecaster's own chance of this, stated with the estimate: 80%; the middle value sits exactly at the limit.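

In this assay compound 4 gives > 100000 nM, which is a limit and not a number. No step from compound 1, compound 2 or compound 3 to compound 4 can be read, and the series stays at a single limit: the limit of > 100000 nM in this assay, at which 4 of the 4 values shown sit.

The compounds shown leave open whether amino in place of nitro changes the read-out at all.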